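Series notes: aryl to benzyloxy exchange on the core

The source may report more compounds than this note shows. Statements on the series, on what has been measured and on what is new or still open speak of the compounds shown alone.

Two compounds have numbers in a functional assay on HEK293 cells for agonist activity at G-protein coupled receptor 39 (Homo sapiens), read by scintillation proximity assay and inositol phosphate accumulation, with a stated time of 75 min, in the presence of a further agent that is not named here; on this read-out lower numbers stand for an effect already at smaller amounts and higher numbers for an effect only at larger amounts of compound. Compound 1 `Cc1nn(-c2ncnc3nc[nH]c23)c2c1C(c1ccc(OC(C)C)cc1)CC(=O)N2` gives 18 nM in this assay, the lower of the two values. Compound 2 `CC(C)(C)c1cc(C(=O)N/N=C/c2ccc(O)cc2O)[nH]n1`, built on a different scaffold, gives 240 nM in this assay, a gap to compound 1 that lies beyond the usual scatter. Among the measured compounds shown here, no pair of measured compounds differs in a single place, so no measured step is available to guide the next change.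

Compound 3 `Cc1nn(-c2ncnc3nc[nH]c23)c2c1C(OCc1ccccc1F)CC(=O)N2` keeps the core of compound 1 and differs only as counted here: (2-fluorobenzyl)oxy in place of 4-isopropoxyphenyl on a saturated ring carbon. The group that leaves is attached to the saturated carbon through its aromatic ring; the group that enters is attached through its oxygen, so the aromatic ring is set further out.

With no measured step of this kind in the series, the expectation for compound 3 rests on the size of the change alone: a shift toward a higher number is estimated, a 4.4-fold higher number from compound 1 to compound 3 (0.65 log units; beyond the scatter), larger than the scatter but not drastic. Compound 3 is thus expected to give about 80 nM in this assay, within a range of 15 nM to 400 nM.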

Compound 3, half-maximal effective concentration: 4 nM
For compound 3 the middle estimate is 20-fold (1.30 log units) above the measured one; measured number below the stated range.
By their numbers in this assay, from the lowest: compound 3; then compound 1; then compound 2.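

In this assay, among the compounds shown here, (2-fluorobenzyl)oxy in place of 4-isopropoxyphenyl on a saturated ring carbon gives a 4.5-fold lower number from compound 1 to compound 3 (0.65 log units; beyond the scatter), the first step that changes a single place. This position of the shared core therefore accepts an aromatic ring attached through oxygen as well as one attached directly, and on this read-out the exchange brings a modest gain rather than a loss. The data at hand give no explanation for this step.

From the compounds shown here alone, the link through oxygen, the added carbon before the ring and the fluorine all change together in this one step, so their separate shares remain open. A plain benzyloxy group, or a benzylamine with nitrogen in place of the linking oxygen, on the same carbon would begin to separate them.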